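Working notes: from compound 2 to compound 3

This account rests on a few compounds, and the source may have more. Where it says the series, first, only, none or still open, it means among the compounds named here.

For the measured compounds named here, compound 2 `CN(C(=O)NC(=O)c1ccc(C(F)(F)F)cc1)c1nc(C(F)(F)F)c(C(=O)N/N=C/c2cc(C(F)(F)F)cc(C(F)(F)F)c2)s1` is the only compound of the pair measured to a number in a functional assay on BCG823 cells (Homo sapiens) for inhibition, read by MTT assay, with a stated time of 72 h (on this read-out higher numbers stand for weaker inhibition and lower numbers for stronger inhibition), where compound 2 gives 1.77 ug/mL. Compound 1 `CN(C(=O)NC(=O)c1ccc(Cl)cc1Cl)c1nc(C(F)(F)F)c(C(=O)N/N=C/c2cc(C(F)(F)F)cc(C(F)(F)F)c2)s1` reaches only a limit of the assay in this assay, > 100 ug/mL. Going by the values given here, the single measured step, an at least 56-fold lower number from compound 1 to compound 2 (1.75 log units; beyond the scatter), is the only one that bears on the change to compound 3 `CN(C(=O)NC(=O)c1c(F)cccc1F)c1nc(C(F)(F)F)c(C(=O)N/N=C/c2cc(C(F)(F)F)cc(C(F)(F)F)c2)s1`, which is 2,6-difluorophenyl in place of 4-(trifluoromethyl)phenyl on a carbonyl carbon. That measured step exchanged one aryl group for another on the same carbonyl carbon and was large, with compound 1 sitting at the limit of > 100 ug/mL in this assay, at which 1 of the 2 values shown sits. The move to compound 3 again exchanges the aryl on that carbonyl carbon, this time for a 2,6-difluorophenyl, so the number in this assay is expected to move back upward, by an estimated 6.8-fold higher number from compound 2 to compound 3 (0.83 log units; beyond the scatter). Compound 3 is therefore expected to give 12 ug/mL in this assay, with an estimated range from 3 ug/mL to 60 ug/mL, and a further limit rather than a number remains possible.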

Compound 3, half-maximal inhibitory concentration: 5.28 ug/mL
The estimate for compound 3 lay 2.3-fold (0.36 log units) above the measured number; the measured number falls inside the stated range.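

In this assay, the carbonyl carbon on the amide-type nitrogen now carries three different aryl groups, and a measured number is not confined to 4-(trifluoromethyl)phenyl: 2,6-difluorophenyl also gives one, with a 3.0-fold higher number from compound 2 to compound 3 (0.47 log units; beyond the scatter). This modest step is much smaller than the change from the 2,4-dichlorophenyl compound, with an at least 18-fold lower number from compound 1 to compound 3 (1.27 log units; beyond the scatter), so among the three compounds shown, the two with fluorine-bearing aryl groups give numbers and compound 1 stands apart. Compound 1 remains a limit of the assay and not a number, so both steps from it give only a minimum size: the limit of > 100 ug/mL in this assay, at which 1 of the 3 values shown sits.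

Since 2,4-dichlorophenyl differs from the other two groups in both its halogen and its substitution pattern, the compounds shown cannot separate these two features as the source of the gap to compound 1. Also open, going by these compounds, is how much the aryl substituents matter at all, and whether an unsubstituted phenyl or a saturated cyclohexyl on the same carbonyl carbon would stay near compound 2 and compound 3 or fall towards compound 1.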